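From methyl to isopropyl on a saturated chain carbon

The source may hold more compounds than are shown below. What is called first, only, known or untested is meant among the compounds shown, and "the series" means these compounds.

In a physicochemical assay for solubility (on this read-out higher numbers stand for higher solubility and lower numbers for lower solubility), compound 1 (`Cc1nc(C)c(COC(=O)NCC(=O)Oc2ccc(-c3cc(=O)c4c(O)c(O)c(O)cc4o3)cc2)nc1C`) gives 454 ug/mL and compound 2 (`Cc1nc(C)c(COC(=O)N[C@H](C)C(=O)Oc2ccc(-c3cc(=O)c4c(O)c(O)c(O)cc4o3)cc2)nc1C`) gives 799 ug/mL, two values within the scatter of each other. Compound 3 (`Cc1nc(C)c(COC(=O)N[C@@H](C(=O)Oc2ccc(-c3cc(=O)c4c(O)c(O)c(O)cc4o3)cc2)C(C)C)nc1C`) has not yet been measured. It departs from compound 2 in one place: isopropyl in place of methyl on a saturated chain carbon bound to an amide-type nitrogen and a carbonyl carbon. Among the measured compounds shown here, one measured step bears on this, methyl in place of hydrogen at that same place: a 1.8-fold higher number from compound 1 to compound 2 (0.25 log units; within the scatter). For the measured compounds named here, that step stays within the scatter, and no measurement yet covers isopropyl there. In this assay no step beyond the scatter is therefore expected, and no direction is firmly favoured. The expected step is a 1.3-fold lower number from compound 2 to compound 3 (0.12 log units; within the scatter). Compound 3 is estimated at 600 ug/mL, with an expected range from 250 ug/mL to 1300 ug/mL.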

Compound 3, solubility: 252 ug/mL
Beside the measured number, compound 3's estimate is 2.4-fold (0.38 log units) above it; measured number inside the range.
By their numbers in this assay, from the lowest: compounds 3, 1 and 2 (each within the scatter of the next, the first and the last beyond it).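

In this assay, this position on a saturated chain carbon bound to an amide-type nitrogen and a carbonyl carbon now shows a step beyond the scatter, modest in size, when isopropyl takes the place of methyl (a 3.2-fold lower number from compound 2 to compound 3 (0.50 log units; beyond the scatter)). Hydrogen and methyl had stayed within the scatter of each other, and hydrogen and isopropyl do too (a 1.8-fold lower number from compound 1 to compound 3 (0.26 log units; within the scatter)), so only the methyl and isopropyl pair separates and the three compounds show no steady trend along hydrogen, methyl and isopropyl. Nothing available explains this step.

On these data alone, whether a longer chain, such as n-butyl, would follow isopropyl at this place remains open. So does the outcome with an amine or a carboxylic acid on that chain.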